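A few compounds are considered here, and "the series" means these few. Any claim that something is new, unique, unknown or untested is made for them only; others in the source may bear on it.

In an ADME assay on MRC5 cells (Homo sapiens) for cytotoxicity, read by fluorescence and resazurin assay, with a stated time of 24 h (a lower number here means a stronger inhibitor, a higher number a weaker inhibitor), compound 1 (`CCOC(=O)c1c(C(C)C)oc2nc(N3CCCC3)ccc12`) shows > 330000 nM as a limit only. Compound 2 (`CCOC(=O)c1c(C)oc2nc(N3CCCC3)ccc12`) likewise shows > 364000 nM as a limit only. For compound 3 (`CNC(=O)c1c(C)oc2nc(N3CCCC3)ccc12`) the entry is "not determined" (no result reported) and gives no number. Compound 2 thus stands with only a limit and no measured number to set it against. Compound 4 (`CCOC(=O)c1c(-c2ccccc2)oc2nc(N3CCCC3)ccc12`) differs from compound 2 by phenyl in place of methyl on an aromatic carbon. Going by the values given here, the one measured step bearing on this change is a step that the two limits leave unreadable from compound 1 to compound 2 with methyl in place of isopropyl, and it sets neither size nor direction. The expected change is an at least 1.8-fold lower number from compound 2 to compound 4 (0.26 log units; that floor lies within the scatter) and this modest move toward a lower number is only tentative. In this assay compound 4 is estimated at 200000 nM with an expected range from 60000 nM to 400000 nM. Compound 4 may again give only a limit.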

Compound 4, half-maximal inhibitory concentration: > 297000 nM
Compound 4: no number, only a limit (the forecaster's own chance of this, stated with the estimate: 60%); middle value at least 1.4-fold (0.17 log units) from the limit.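

Going by these compounds alone, compound 1, compound 2 and compound 4 each give only a limit in this assay, so no step among them can be read. The compounds shown leave open whether methyl, isopropyl or phenyl on this aromatic carbon changes the cytotoxicity at all.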